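A few compounds are considered here, and "the series" means these few. Any claim that something is new, unique, unknown or untested is made for them only; others in the source may bear on it.

Measured compounds in an assay on CHO cells for displacement of a labelled ligand from adenosine receptor A1 (Homo sapiens), read by scintillation counting, with a stated time of 120 min, tested at 1 uM; a lower number here means less inhibition, a higher number more inhibition at the concentration tested (going by the name of the read-out):
compound 1 `Cc1nc2sc(Nc3ccccc3)nc2c(=O)[nH]1` — 24%
compound 2 `COc1ccc(Nc2nc3c(=O)[nH]c(C)nc3s2)cc1` — 1%
compound 3 `Cc1ccc(Nc2nc3c(=O)[nH]c(C)nc3s2)cc1` — 20%

Compound 3 stands second highest of the three. Its nearest neighbour is compound 1: the step of a number 4 percentage points lower from compound 1 to compound 3 (within the scatter) lies within the scatter, so the two cannot be ordered. Its furthest is compound 2, and the step of a number 19 percentage points higher from compound 2 to compound 3 (beyond the scatter) is beyond the scatter, the only clear separation in the set.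

Compound 4 `Cc1nc2sc(Nc3ccc(Cl)cc3)nc2c(=O)[nH]1` is the next member. The change from compound 3: chloro in place of methyl on an aromatic carbon

Going by the values given here, no measured step involves chloro, so nothing bears on it directly. The steps that are related concern the same position of the ring: a number 4 percentage points lower from compound 1 to compound 3 (within the scatter) shows methyl in place of hydrogen changing little, while a number 23 percentage points lower from compound 1 to compound 2 (beyond the scatter) shows methoxy in place of hydrogen lowering the read-out. A small group entering at this position has so far either left the number where it was or lowered it; none has raised it. For compound 4 the expected step is therefore a number 2 percentage points lower from compound 3 to compound 4 (within the scatter), small and not clearly beyond the scatter, with the downside open. The estimate for compound 4 in this assay is 18%, in the range 3% to 38%.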

Compound 4, a percentage reported as inhibition, at one concentration (the size of the read-out at that concentration, not a potency): 33%
Estimate against measurement, compound 4: 15 percentage points below, and the stated range covers the measured number.
By their numbers in this assay, from the lowest: compound 2; then compounds 3, 1 and 4 (each within the scatter of the next, the first and the last beyond it).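

Chloro at this place on the six-membered aromatic ring separates clearly from the other two substituents in this assay: the change from methyl gives a number 13 percentage points higher from compound 3 to compound 4 (beyond the scatter) and the change from methoxy gives a number 32 percentage points higher from compound 2 to compound 4 (beyond the scatter). Against hydrogen the same substitution gives a number 9 percentage points higher from compound 1 to compound 4 (within the scatter), so compound 4 and compound 1 cannot be ordered, and no substituent at this position has yet been shown to raise the read-out over hydrogen. What is new is that methyl and chloro, though each lies within the scatter of hydrogen, lie beyond the scatter of each other, so the position does distinguish between two groups of one heavy atom each, and nothing at hand accounts for that difference.

As far as these compounds go, whether fluoro, bromo, an amine or a carboxylic acid at this same position would stand clearly above the unsubstituted compound 1 remains open. Also open, from the compounds shown here alone, is whether the order of chloro, methyl and methoxy holds when the same groups sit elsewhere on the ring, or when the methyl on the shared core gives way to a longer chain.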